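Solubility Outlook for a Hydroxycyclohexyl Amine Analogue

The source may report more compounds than this note shows. Statements on the series, on what has been measured and on what is new or still open speak of the compounds shown alone.

Compound 1 `CC(C)(O)CNCCCOc1ccc([C@H]2CC[C@]3(CC2)OOC2(O3)C3CC4CC(C3)CC2C4)cc1` gives > 100 ug/mL in a physicochemical assay for solubility, read by nephelometry, measured as kinetic solubility, with a stated time of 30 min (a higher number here means a more soluble compound, a lower number a less soluble compound), which is a limit of the assay.
Compound 2 `c1cc([C@H]2CC[C@]3(CC2)OOC2(O3)C3CC4CC(C3)CC2C4)ccc1OC1CCNCC1` gives > 100 ug/mL in this assay, also a limit.

Compound 1 stands only at a limit in this assay because of the limit of > 100 ug/mL in this assay, at which 2 of the 2 values shown sit. For the measured compounds named here, the one measured step, a step that the two limits leave unreadable from compound 1 to compound 2, is therefore of unknown size. Compound 3 `O[C@H]1CC[C@H](NCCCOc2ccc([C@H]3CC[C@]4(CC3)OOC3(O4)C4CC5CC(C4)CC3C5)cc2)CC1` differs from compound 1 by 4-hydroxycyclohexyl in place of 2-hydroxy-2-methylpropyl on an amine nitrogen. Going by the values given here, no measured step reads on this change, so no step beyond the scatter is expected. The expected step is a step that the limit leaves unreadable from compound 1 to compound 3. Compound 3 is expected to give 120 ug/mL, within a range from 50 ug/mL to 300 ug/mL, most likely reported again as a limit.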

Compound 3, solubility: > 100 ug/mL
Compound 3: only a limit was reported; the forecaster's own chance of this, stated with the estimate: 70%; the middle value does not contradict the limit.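

For the compounds shown here, compound 3, like compound 1 and compound 2, gives only a limit in this assay, so no step among them can be read: the limit of > 100 ug/mL in this assay, at which 3 of the 3 values shown sit. The compounds shown leave open how far each lies past that limit.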